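The source may report more compounds than this note shows. Statements on the series, on what has been measured and on what is new or still open speak of the compounds shown alone.

In a functional assay on THP-1 cells (Homo sapiens) for inhibition, read by ELISA, with stated times of 30 min and 24 h, tested at 1 uM (a lower number here means a weaker effect, a higher number a stronger effect of the compound at the concentration tested), compound 1 `COc1cc(OC)c(C(=O)c2ccccc2F)c(O)c1CN1CCCC1` gives 15%. Compound 2 `COc1cc(O)c(C(=O)c2cccc(Cl)c2)c(OC)c1` gives 31% in this assay, the higher of the two measured values, standing above compound 1 by a gap that lies beyond the usual scatter. Compound 3 `COc1cc(OC)c(C(=O)c2cccc(Cl)c2)c(O)c1CN1CCCC1` has not been measured; it differs from compound 2 by (pyrrolidin-1-yl)methyl in place of hydrogen on an aromatic carbon. Within the data shown here, no measured pair isolates this change, so its effect is unknown from the data. The step of a number 7 percentage points lower from compound 2 to compound 3 (within the scatter) is expected to be small, within the scatter or slightly downward. Compound 3 is therefore estimated at 24%, with a range from 8% to 42%.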

Compound 3, a percentage reported as activity, at one concentration (the size of the read-out at that concentration, not a potency): 41%
The estimate for compound 3 lay 17 percentage points below the measured number, and the stated range covers the measured number.
By their numbers in this assay, from the lowest: compound 1; then compounds 2 and 3 (each within the scatter of the next).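

Placing (pyrrolidin-1-yl)methyl on the aromatic carbon ortho to a hydroxy group is tolerated in this assay, with a number 10 percentage points higher from compound 2 to compound 3 (within the scatter), so this position accepts the added ring and its nitrogen without a clear loss of read-out. With that group present, the group on the carbonyl carbon does matter: 3-chlorophenyl in place of 2-fluorophenyl gives a number 26 percentage points higher from compound 1 to compound 3 (beyond the scatter). No measurement here explains either step.

Going by these compounds, whether a carboxylic acid or an open-chain amine such as dimethylaminomethyl would fare the same at this position stays open. So does the effect of that phenyl change in compounds lacking the pyrrolidine.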